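The compounds below may be only part of what the source reports. "The series", "measured", "known", "first", "only" and "open" are said of these compounds alone.

Measured compounds in an ADME assay on HeLa cells (Homo sapiens) for cytotoxicity, read by ATP content, with a stated time of 3 days; on this read-out lower numbers stand for higher toxicity in this test and higher numbers for lower toxicity in this test:
compound 1, `COc1ccc(-n2c(=O)n(Cc3cc4cc(Cl)ccc4n3CCCC#N)c3cnccc32)cc1`: > 50000 nM
compound 2, `CS(=O)(=O)CCCn1c(Cn2c(=O)n(C3CC3)c3ccncc32)cc2cc(Cl)ccc21`: > 50000 nM
compound 3, `CS(=O)(=O)CCCn1c(Cn2c(=O)n(C3CC3)c3ccncc32)cc2ccccc21`: > 100000 nM

The value of compound 1 is a limit of this assay, not a number. The value of compound 2 is likewise a limit. The value of compound 3 is a limit as well. Compound 1 therefore stands at the limit of > 50000 nM in this assay, at which 2 of the 3 values shown sit, while compound 3 stands at the limit of > 100000 nM in this assay, at which 1 of the 3 values shown sits. Within the data shown here, the one pair differing in a single place gives a step that the two limits leave unreadable from compound 2 to compound 3, so no measured step has a readable size.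

Compound 4, `N#CCCCn1c(Cn2c(=O)n(-c3ccc(OC(F)(F)F)cc3)c3ccncc32)cc2cc(Cl)ccc21`, differs from compound 1 by trifluoromethyl in place of methyl on an oxygen on an aromatic ring. Among the measured compounds shown here, no measured step touches this change; the only step on record concerns a chloro group and cannot be read. Since compound 1 sits at a limit, compound 4 is expected to sit at or near the same limit, with a step that the limit leaves unreadable from compound 1 to compound 4 as the expected step. The estimate for compound 4 in this assay is 80000 nM, within 30000 nM to 200000 nM.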

Compound 4, half-maximal cytotoxic concentration: > 50000 nM
Compound 4: only a limit was reported (the forecaster's own chance of this, stated with the estimate: 75%); the middle value is on the limit's open side.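

In this assay compound 4 gives > 50000 nM, a limit and not a number. Among these compounds, compound 1 gives > 50000 nM, also a limit, so no step between compound 1 and compound 4 can be read. The compounds shown leave open whether trifluoromethoxy in place of methoxy shifts the half-maximal cytotoxic concentration at all.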